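A few compounds are considered here, and "the series" means these few. Any claim that something is new, unique, unknown or untested is made for them only; others in the source may bear on it.

Measured compounds:

Compound 1, `COc1cc2c(Oc3ccc(NC(=O)c4cc(-c5ccccc5)ccn4)cc3F)ccnc2cc1OCCCN1CCN(C)CC1`: 150 nM
Compound 2, `COc1cc2c(Oc3ccc(NC(=O)c4cc(-c5ccc(F)cc5)ccn4)cc3F)ccnc2cc1OCCCN1CCN(C)CC1`: 510 nM
Compound 3, `COc1cc2c(Oc3ccc(NC(=O)c4nccc(-c5ccc(F)cc5)n4)cc3F)ccnc2cc1OCCCN1CCCCC1`: 930 nM

All three were tested in a functional assay on MKN-45 cells (Homo sapiens) for cytotoxicity, read by MTT assay, with a stated time of 72 h; a lower number here means a stronger inhibitor, a higher number a weaker inhibitor. Compound 1 and compound 2 share one core; compound 3 carries a different one, and the difference between the two cores is not broken down here. Compound 4, `COc1cc2c(Oc3ccc(NC(=O)c4nccc(-c5ccc(F)cc5F)n4)cc3F)ccnc2cc1OCCCN1CCCCC1`, has the core of compound 3 and is still to be measured.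

Going from compound 1 to compound 2 the change is fluoro in place of hydrogen on an aromatic carbon, and it gave a 3.4-fold higher number from compound 1 to compound 2 (0.53 log units; beyond the scatter). Going from compound 3 to compound 4 the change is fluoro in place of hydrogen on an aromatic carbon. This is the same kind of change, but not the same: in compound 2 the new fluoro sits para to a large group, while in compound 4 it sits ortho to a large group and meta to a fluoro group that is already present.

Within the data shown here, only one earlier step of this kind is known, and it was measured on another core, so it is a weak guide. Because compound 3 already stands at 930 nM, a further weakening of the same modest size or smaller is expected, a 1.6-fold higher number from compound 3 to compound 4 (0.21 log units; within the scatter). Compound 4 is therefore estimated at 1500 nM in this assay, with a likely range from 600 nM to 3800 nM.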

Compound 4, half-maximal inhibitory concentration: 1120 nM
Estimate against measurement, compound 4: 1.3-fold (0.13 log units) above, within the range that was stated.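

In this assay, replacing 4-fluorophenyl with 2,4-difluorophenyl gave a 1.2-fold higher number from compound 3 to compound 4 (0.08 log units; within the scatter), so the two compounds cannot be told apart here. Placed beside the earlier step, this shows that the size of the change did not carry over from one core to the other: the same change on two cores in this assay, a 3.4-fold higher number (0.53 log units; beyond the scatter) from compound 1 to compound 2 and a 1.2-fold higher number (0.08 log units; within the scatter) from compound 3 to compound 4, 2.8-fold (0.45 log units) apart, beyond the scatter of two such steps. It does not show that the core alone sets the size of the step, since each core offers a single pair and the new fluoro does not stand at the same place on the ring in the two steps.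

The compounds shown leave open what the same fluoro would do on each core if it stood at one identical place on the ring, which would separate the effect of the core from that of the position. Also open, from the compounds shown here alone, is how other small groups at that place, such as chloro, methyl or methoxy, would compare with fluoro on either core.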